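The compounds below may be only part of what the source reports. "The series", "measured", "known", "first", "only" and "open" are said of these compounds alone.

Compound 1 `O=C(Nc1cccc(F)c1)c1cc(=O)[nH]c2cc(F)ccc12`: > 20000 nM
Compound 2 `O=C(Nc1cccc(F)c1)c1cc(=O)[nH]c2cc(-c3ccc(F)nc3)ccc12`: > 20000 nM

In a functional assay on KYSE-410 cells (Homo sapiens) for antiproliferative activity, read by MTT assay, with a stated time of 72 h (a lower number here means a stronger inhibitor, a higher number a weaker inhibitor), compound 1 gives > 20000 nM, which is a limit and not a number. Compound 2 also gives a limit, > 20000 nM. Within the data shown here, the series so far shows only (the limit of > 20000 nM in this assay, at which 2 of the 2 values shown sit).

Compound 3 `CCN(CC)CCCC(C)Nc1ccc(NC(=O)c2cc(=O)[nH]c3cc(F)ccc23)cc1F` carries (4-(diethylamino)-1-methylbutyl)amino in place of hydrogen on an aromatic carbon, ortho to a fluoro group. Among the measured compounds shown here, the one measured step, a step that the two limits leave unreadable from compound 1 to compound 2, replaces a fluoro group rather than this hydrogen and has no readable size, so it sets no scale. A tentative move towards stronger inhibition is expected, and compound 3 may also remain at the limit. The expected change is an at least 3.3-fold lower number from compound 1 to compound 3 (0.52 log units; beyond the scatter). For compound 3 the estimate is 6000 nM, with an expected range of 1500 nM to 20000 nM.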

Compound 3, half-maximal inhibitory concentration: > 20000 nM
Compound 3 was reported as a limit; the forecaster's own chance of this, stated with the estimate: 25%; middle value at least 3.3-fold (0.52 log units) from the limit.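

No step can be read between compound 1 and compound 3, since both are limits and not numbers: the limit of > 20000 nM in this assay, at which 3 of the 3 values shown sit.

On these data alone, whether any change to the shared core gives a readable number remains open.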